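The source may hold more compounds than are shown below. What is called first, only, known or untested is meant among the compounds shown, and "the series" means these compounds.

In a functional assay for antagonist activity at transient receptor potential cation channel subfamily V member 1 (Rattus norvegicus) (on this read-out lower numbers stand for stronger inhibition and higher numbers for weaker inhibition), compound 1 `CCCOc1cccnc1-c1ccc(C(=O)Nc2ccc(C(C)(C)C)cc2)cc1` gives 20 nM, the lowest of the two numbers measured, with compound 2 as its nearest neighbour. Compound 2 `CCCNc1cccnc1-c1ccc(C(=O)Nc2ccc(C(C)(C)C)cc2)cc1` gives 37 nM in this assay, and the step of a 1.9-fold higher number from compound 1 to compound 2 (0.27 log units; within the scatter) is the only measured one. Compound 3 `Cc1nnc(-c2cccnc2-c2ccc(C(=O)Nc3ccc(C(C)(C)C)cc3)cc2)o1` is still to be measured; it differs from compound 1 in one place: 5-methyl-1,3,4-oxadiazol-2-yl in place of propoxy on an aromatic carbon. The known step puts propylamino in place of propoxy and stays within the scatter, so it bears only loosely on the entry of a five-membered aromatic ring with 3 hetero atoms; the expected step of a 2.0-fold higher number from compound 1 to compound 3 (0.30 log units; within the scatter) leans weaker but not firmly beyond the scatter. Compound 3 is estimated at 40 nM, in a range from 10 nM to 160 nM.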

Compound 3, half-maximal inhibitory concentration: 34 nM
The estimate for compound 3 lay 1.2-fold (0.07 log units) above the measured number, within the range that was stated.
By their numbers in this assay, from the lowest: compounds 1, 3 and 2 (each within the scatter of the next).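

In this assay this position, on an aromatic carbon ortho to a large group, accepts a five-membered aromatic ring as well as an open chain: a 1.7-fold higher number from compound 1 to compound 3 (0.23 log units; within the scatter) and a 1.1-fold lower number from compound 2 to compound 3 (0.04 log units; within the scatter) both stay within the scatter. Propoxy and propylamino alone could not show this, since neither carries a ring. Nothing available here explains why the three groups read alike.

The compounds shown leave open whether a longer chain, a carboxylic acid or a phenyl ring at this place would also stay within the scatter. They also leave open what the methyl on the 5-methyl-1,3,4-oxadiazol-2-yl group contributes.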